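From amino to methoxy on compound 1

The compounds below may be only part of what the source reports. "The series", "measured", "known", "first", "only" and "open" are said of these compounds alone.

In a physicochemical assay for solubility, at pH 7.4 (a lower number here means a less soluble compound, a higher number a more soluble compound), compound 1 (`Cc1cc(NC(=O)Nc2ccccc2N)c2ccccc2n1`) stands highest of the two measured numbers at 51800 nM and compound 2 (`Cc1cc(NC(=O)Nc2ccc(F)cc2)c2ccccc2n1`) gives 3700 nM in the same read-out. Compound 3 (`COc1ccccc1NC(=O)Nc1cc(C)nc2ccccc12`) is still unmeasured and differs from compound 1 by methoxy in place of amino on an aromatic carbon as methoxy in place of amino on an aromatic carbon, ortho to a large group. Going by the values given here, the only measured step that also removes the amino group is a 14-fold lower number from compound 1 to compound 2 (1.15 log units; beyond the scatter) and it is large, so a smaller step in the same direction is expected in this assay for compound 3. The estimated step is a 4.3-fold lower number from compound 1 to compound 3 (0.64 log units; beyond the scatter) and it rests on that single comparison. For compound 3 the estimated value is 12000 nM with an expected range from 3500 nM to 40000 nM in this series.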

Compound 3, solubility: 100 nM
Compound 3: middle estimate off by 120-fold (2.08 log units), on the high side; measured number below the stated range.
By their numbers in this assay, from the lowest: compound 3; then compound 2; then compound 1.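

With the aromatic carbon ortho to a large group still substituted, methoxy in place of amino gives a 520-fold lower number from compound 1 to compound 3 (2.71 log units; beyond the scatter) in this assay. This single-place change shows that a large step at this position does not need the substituent to be removed or moved, as it was in a 14-fold lower number from compound 1 to compound 2 (1.15 log units; beyond the scatter). No measurement on hand explains the step.

Still open, from the compounds shown here alone, is whether the step follows the loss of amino or the arrival of methoxy. A hydroxyl or dimethylamino group on this carbon would help separate the two.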